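Swapping the sulfur-bearing group of compound 3

This account rests on a few compounds, and the source may have more. Where it says the series, first, only, none or still open, it means among the compounds named here.

Measured so far in a functional assay on VCaP cells (Homo sapiens) for antiproliferative activity, read by propidium iodide staining, with a stated time of 96 h; on this read-out lower numbers stand for stronger inhibition and higher numbers for weaker inhibition:
compound 1 `CC(O)(CSc1ccc(S(F)(F)(F)(F)F)cc1)C(=O)Nc1ccc(C#N)cc1C(F)(F)F`: 20500 nM
compound 2 `CC(O)(CSc1cccc(C(F)(F)F)c1)C(=O)Nc1cccc(S(F)(F)(F)(F)F)c1`: 20200 nM
compound 3 `CC(O)(CSc1cc(C(F)(F)F)cc(C(F)(F)F)c1)C(=O)Nc1cccc(S(F)(F)(F)(F)F)c1`: 4000 nM

Compound 3 has the lowest number of the three, with both others beyond the scatter from it. Next comes compound 4 `CC(O)(CSc1cc(C(F)(F)F)cc(C(F)(F)F)c1)C(=O)Nc1cccc(C(F)(F)C(F)(F)F)c1`, which carries 1,1,2,2,2-pentafluoroethyl: a group of 7 heavy atoms (2 carbon, 5 fluorine; no ring) in place of a group of 6 heavy atoms (5 fluorine, 1 sulfur; no ring), on an aromatic carbon. Among the measured compounds shown here, the one measured step, a 5.1-fold lower number from compound 2 to compound 3 (0.70 log units; beyond the scatter), is a trifluoromethyl change at another place, so it bears only indirectly. For the measured compounds named here, no measured step replaces this group, so no step beyond the scatter is expected in this assay, and the direction stays open. For compound 4 the estimated value is 4500 nM, with an expected range of 1800 nM to 11000 nM. The expected change is a 1.1-fold higher number from compound 3 to compound 4 (0.05 log units; within the scatter).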

Compound 4, half-maximal inhibitory concentration: 8600 nM
Beside the measured number, compound 4's estimate is 1.9-fold (0.28 log units) below it; the measured number falls inside the stated range.
By their numbers in this assay, from the lowest: compound 3; then compound 4; then compounds 2 and 1 (each within the scatter of the next).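

At this aromatic carbon, 1,1,2,2,2-pentafluoroethyl in place of the group of 5 fluorine and 1 sulfur atoms gives a 2.2-fold higher number from compound 3 to compound 4 (0.33 log units; beyond the scatter) in this assay, so the position responds to the choice of group, though only modestly. Among the compounds shown here, the earlier step, a 5.1-fold lower number from compound 2 to compound 3 (0.70 log units; beyond the scatter), lay at another place, which makes this the first reading at this position. Nothing available explains the difference between the two groups.

As far as these compounds go, whether an amine or a heptafluoropropyl chain at this carbon would move the number further stays open. So does whether the step holds when the sulfur-bearing side of the molecule carries other groups.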